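Compound 3 to compound 4: losing the nitro group

This account rests on a few compounds, and the source may have more. Where it says the series, first, only, none or still open, it means among the compounds named here.

Measured in an ADME assay on J774 cells (Mus musculus) for cytotoxicity, read by fluorescence and resazurin assay, with a stated time of 24 h; a lower number here means that less compound is tolerated, a higher number that more compound is tolerated:
Compound 1 `O=[N+]([O-])c1ccc(S(=O)(=O)Nc2nccc3ccccc23)cc1`: 41300 nM
Compound 2 `Cc1cc2cc(NS(=O)(=O)c3cccc4ccccc34)ccc2[nH]1`: 24600 nM
Compound 3 `O=[N+]([O-])c1ccc(S(=O)(=O)Nc2ccc3ncsc3c2)cc1`: >= 300000 nM

Compound 3 stands at >= 300000 nM, and this is a limit of the assay, not a number. That reading is the limit of >= 300000 nM in this assay, at which 1 of the 3 values shown sits. The other two readings lie within the usual scatter of each other, with compound 1 at 41300 nM and compound 2 at 24600 nM.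

Compound 4 `O=S(=O)(Nc1ccc2ncsc2c1)c1ccccc1` has not yet been measured. It is compound 3 with hydrogen in place of nitro on an aromatic carbon, para to a large group: hydrogen in place of nitro on an aromatic carbon. Among the measured compounds shown here, no pair of measured compounds shows what this exchange does in this assay, so the size of the step can only be judged loosely. The expectation is that compound 4 stays in the high range set by compound 3 at >= 300000 nM, with a modest fall possible. The expected change is an at least 1.7-fold lower number from compound 3 to compound 4 (0.24 log units; that floor lies within the scatter), though the limit on compound 3 makes this estimated size uncertain. For compound 4 the estimated value is 170000 nM, with an expected range from 50000 nM to 300000 nM.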

Compound 4, half-maximal cytotoxic concentration: >= 300000 nM
Compound 4: no number, only a limit; the forecaster's own chance of this, stated with the estimate: 45%; middle value at least 1.7-fold (0.24 log units) from the limit.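

In this assay compound 4 gives >= 300000 nM, a limit of the assay and not a number. Compound 3 also stands at a limit, so no step can be read from one compound to the other: the limit of >= 300000 nM in this assay, at which 2 of the 4 values shown sit.

The compounds shown leave open whether hydrogen in place of nitro changes tolerance at all, and in which direction.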